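A few compounds are considered here, and "the series" means these few. Any claim that something is new, unique, unknown or untested is made for them only; others in the source may bear on it.

Compound 3 `COc1ccc(C(=O)CCCCCCC(=O)NO)cc1` gives 450 nM in an assay on isolated protein for inhibition of histone deacetylase 8 (Homo sapiens) (a lower number here means a stronger inhibitor, a higher number a weaker inhibitor), the second highest of the three numbers to hand. Compound 1 `O=C(CCCCCCC(=O)c1ccccc1)NO` gives 500 nM in this assay, and a 1.1-fold lower number from compound 1 to compound 3 (0.05 log units; within the scatter). Compound 2 `O=C(CCCCCCCC(=O)c1ccccc1)NO` gives 65 nM in this assay, and a 7.7-fold lower number from compound 1 to compound 2 (0.89 log units; beyond the scatter). Compound 4 `COc1ccc(C(=O)CCCCCCCC(=O)NO)cc1` is not yet measured; it differs from compound 3 by (hydroxycarbamoyl)methyl in place of hydroxycarbamoyl on a saturated chain carbon, six bonds along the chain from a carbonyl carbon, the same change as that from compound 1 to compound 2. That step bears directly on the expectation, so a step of similar size and direction, lowering the number beyond the scatter, is expected in this assay. For compound 4 the expected step is a 6.4-fold lower number from compound 3 to compound 4 (0.81 log units; beyond the scatter). Compound 4 is therefore estimated at 70 nM, with a range from 30 nM to 170 nM.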

Compound 4, half-maximal inhibitory concentration: 15 nM
For compound 4 the middle estimate is 4.7-fold (0.67 log units) above the measured one, and the stated range ends above it.
By their numbers in this assay, from the lowest: compound 4; then compound 2; then compounds 3 and 1 (each within the scatter of the next).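

In this assay, (hydroxycarbamoyl)methyl in place of hydroxycarbamoyl gives a larger drop on the core of compound 3, with a 30-fold lower number from compound 3 to compound 4 (1.48 log units; beyond the scatter), so the size of this change depends on the core: the same change on two cores in this assay, a 7.7-fold lower number (0.89 log units; beyond the scatter) from compound 1 to compound 2 and a 30-fold lower number (1.48 log units; beyond the scatter) from compound 3 to compound 4, 3.9-fold (0.59 log units) apart, beyond the scatter of two such steps Methoxy in place of hydrogen on an aromatic carbon, which had no effect beyond the scatter with hydroxycarbamoyl on the chain, now gives a 4.3-fold lower number from compound 2 to compound 4 (0.64 log units; beyond the scatter): the same change on two cores in this assay, a 1.1-fold lower number (0.05 log units; within the scatter) from compound 1 to compound 3 and a 4.3-fold lower number (0.64 log units; beyond the scatter) from compound 2 to compound 4, 3.9-fold (0.59 log units) apart, beyond the scatter of two such steps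

Open, from the compounds shown here alone, is whether 2-(hydroxycarbamoyl)ethyl lowers the number further on either core. Also open, going by these compounds, is whether a chlorine or a dimethylamino group in place of methoxy shows the same dependence on chain length.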